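The source may report more compounds than this note shows. Statements on the series, on what has been measured and on what is new or still open speak of the compounds shown alone.

Compound 1 `O=C(O)c1ccc(-c2cccc(COc3ccc4c(c3)CN(C3CCCC3)C4=O)c2)c(Cl)c1`: 110 nM
Compound 2 `O=C1c2ccc(OCc3cccc(-c4ccc(C(F)(F)F)cc4F)c3)cc2CN1C1CCCC1`: in an assay on HEK293 cells for positive allosteric modulation of metabotropic glutamate receptor 2 (Rattus norvegicus), read by thallium flux (on this read-out higher numbers stand for an effect only at larger amounts of compound and lower numbers for an effect already at smaller amounts), compound 2 reaches only the assay limit > 5000 nM
Compound 3 `COc1ccc(C(=O)O)cc1-c1cccc(COc2ccc3c(c2)CN(C2CCCC2)C3=O)c1`: 80 nM

Compound 3 holds the lowest of the two plain numbers in this assay; compound 1 sits close, and the step of a 1.4-fold lower number from compound 1 to compound 3 (0.14 log units; within the scatter) stays within the scatter. Compound 4 `O=C(O)c1ccc(Cl)c(-c2cccc(COc3ccc4c(c3)CN(C3CCCC3)C4=O)c2)c1` differs from compound 3 by chloro in place of methoxy on an aromatic carbon. Within the data shown here, the one measured step that also swaps a carboxyphenyl for another carboxyphenyl, a 1.4-fold lower number from compound 1 to compound 3 (0.14 log units; within the scatter), was small. The large steps of an at least 45-fold higher number from compound 1 to compound 2 (1.65 log units; beyond the scatter) and an at least 62-fold lower number from compound 2 to compound 3 (1.79 log units; beyond the scatter) concern the loss or gain of the carboxy group, which compound 4 keeps, so they say little here. For compound 4 in this assay a value of 90 nM is expected, between 40 nM and 250 nM, meaning an expected step of a 1.1-fold higher number from compound 3 to compound 4 (0.05 log units; within the scatter) within the scatter.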

Compound 4, half-maximal effective concentration: 90 nM
The estimate for compound 4 equals the measured number at the digits printed; low and high end bracket the measured number.
By their numbers in this assay, from the lowest: compounds 3, 4 and 1 (each within the scatter of the next). At a limit, above all of these: compound 2.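

Swapping methoxy for chloro at this place, para to a carboxy group, gives no change that can be read: a 1.1-fold higher number from compound 3 to compound 4 (0.05 log units; within the scatter). With chloro kept, moving from 4-carboxy-2-chlorophenyl to 5-carboxy-2-chlorophenyl gives none either, so among compounds 1, 3 and 4 the two carboxy placements cannot be told apart: a 1.2-fold lower number from compound 1 to compound 4 (0.09 log units; within the scatter). The large step of an at least 55-fold lower number from compound 2 to compound 4 (1.74 log units; beyond the scatter) rests on a limit for compound 2, not a plain number: the limit of > 5000 nM in this assay, at which 1 of the 4 values shown sits.

Going by these compounds, what an amine or a longer chain would do at this place remains open. So does whether a tetrazole could stand in for the carboxy group.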